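The source may report more compounds than this note shows. Statements on the series, on what has been measured and on what is new or still open speak of the compounds shown alone.

Measured so far in a functional assay on U-87MG ATCC cells (Homo sapiens) for cytotoxicity, read by MTT assay, with a stated time of 72 h; a lower number here means a stronger inhibitor, a higher number a weaker inhibitor:
- compound 1 `COc1ccc(OC)c(/C=N/NC(=O)Nc2ccc(Oc3ccnc(-c4nncn4CCN(C)C)c3)c(F)c2)c1` gives 6400 nM
- compound 2 `CN(C)CCn1cnnc1-c1cc(Oc2ccc(NC(=O)N/N=C/c3ccc(O)c(F)c3)cc2F)ccn1` gives only a limit of the assay, > 100000 nM
- compound 3 `CN(C)CCn1cnnc1-c1cc(Oc2ccc(NC(=O)N/N=C/c3c[nH]c4ccccc34)cc2F)ccn1` gives 690 nM

Compound 3 has the lowest number of the two numbers given; its nearest neighbour is compound 1, with a 9.3-fold lower number from compound 1 to compound 3 (0.97 log units; beyond the scatter). Compound 2 sits at the limit (the limit of > 100000 nM in this assay, at which 1 of the 3 values shown sits), so from compound 2 to compound 3 the step is an at least 140-fold lower number from compound 2 to compound 3 (2.16 log units; beyond the scatter).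

Compound 4 `Cc1cc(/C=N/NC(=O)Nc2ccc(Oc3ccnc(-c4nncn4CCN(C)C)c3)c(F)c2)cc(C)c1O` is not yet measured. It differs from compound 3 in one place: 4-hydroxy-3,5-dimethylphenyl in place of 1H-indol-3-yl on a carbon with a double bond to nitrogen. For the measured compounds named here, two measured steps bear on this. Replacing the indole by a phenol carrying a fluorine gave an at least 140-fold lower number from compound 2 to compound 3 (2.16 log units; beyond the scatter) in reverse, a large rise in the number; replacing it by a dimethoxyphenyl gave a 9.3-fold lower number from compound 1 to compound 3 (0.97 log units; beyond the scatter) in reverse, a modest rise. Compound 4 is again a phenol, now with two methyl groups, so in this assay a clearly higher number than that of compound 3 is expected, a 29-fold higher number from compound 3 to compound 4 (1.46 log units; beyond the scatter). Compound 4 is therefore estimated at 20000 nM, in the range 4000 nM to 100000 nM.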

Compound 4, half-maximal inhibitory concentration: 7710 nM
The estimate for compound 4 lay 2.6-fold (0.41 log units) above the measured number, within the range that was stated.
By their numbers in this assay, from the lowest: compound 3; then compounds 1 and 4 (each within the scatter of the next). At a limit, above all of these: compound 2.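

In this assay, a hydroxy group on the phenyl at this carbon does not by itself bring the large loss, as 4-hydroxy-3,5-dimethylphenyl in place of 3-fluoro-4-hydroxyphenyl gives an at least 12-fold lower number from compound 2 to compound 4 (1.11 log units; beyond the scatter). That step has only a bound, as the value of compound 2 is a limit of the assay and not a number: the limit of > 100000 nM in this assay, at which 1 of the 4 values shown sits. The two substituted phenyl groups of compound 1 and compound 4 read alike, with a 1.2-fold higher number from compound 1 to compound 4 (0.08 log units; within the scatter), whereas the 1H-indol-3-yl keeps the lowest number, with an 11-fold higher number from compound 3 to compound 4 (1.05 log units; beyond the scatter).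

The compounds shown do not separate the effect of the two methyl groups from that of the fluorine, as compound 2 and compound 4 differ in both. Going by these compounds, how an amine or a carboxylic acid on the phenyl would read in this assay remains open.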